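Replacing Nitro with Hydrogen on an Aromatic Carbon

A few compounds are considered here, and "the series" means these few. Any claim that something is new, unique, unknown or untested is made for them only; others in the source may bear on it.

Measured in a functional assay on HOS-TE85 cells (Homo sapiens) for antiproliferative activity, read by MTT assay, with a stated time of 3 days (a higher number here means a weaker inhibitor, a lower number a stronger inhibitor), so far:
compound 1 `C/[N+]([O-])=C1\C(=O)Nc2ccc([N+](=O)[O-])cc21` gives 32000 nM
compound 2 `O=C1Nc2ccc([N+](=O)[O-])cc2/C1=[N+](\[O-])Cc1ccccc1` gives 32000 nM

Compound 2 stands level with compound 1 on these numbers, and neither is separated from the other beyond the scatter. The next compound, compound 3 `O=C1Nc2ccccc2/C1=[N+](\[O-])Cc1ccccc1`, has not been measured. It differs from compound 2 by hydrogen in place of nitro on an aromatic carbon. For the measured compounds named here, the one measured step, no change at the digits printed from compound 1 to compound 2 (within the scatter), concerns phenyl in place of hydrogen on a saturated chain carbon, elsewhere in the structure. Going by the values given here, both measured compounds carry the nitro, so no measurement yet tests its removal. That step therefore offers only weak guidance, and no direction can be favoured. Expected, tentatively, is no change at the digits printed from compound 2 to compound 3 (within the scatter) in this assay, with wide uncertainty. For compound 3 the estimated value is 32000 nM, with an expected range from 11000 nM to 90000 nM overall.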

Compound 3, half-maximal inhibitory concentration: 32000 nM
Compound 3: the middle estimate sits on the measured number at the digits printed; the range from low to high includes it.
By their numbers in this assay, from the lowest: compounds 1, 2 and 3 (each within the scatter of the next).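

For the compounds shown here, compound 3 is the first compound here without the nitro, and in this assay hydrogen in its place on the aromatic carbon gives no change at the digits printed from compound 2 to compound 3 (within the scatter) for this pair. Going by these compounds alone, compounds 1 and 2 both carried the nitro, so only this pair tests the position, and it shows that losing those 3 heavy atoms leaves the printed value in place. No measurement is available that could explain this result.

Still open is whether other groups on this aromatic carbon, such as an amine, a carboxylic acid or a methoxy group, would read the same, as only nitro and hydrogen are shown there. Also open, as far as these compounds go, is whether a longer chain on the double-bonded nitrogen would leave the value where compounds 1, 2 and 3 stand.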